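This account rests on a few compounds, and the source may have more. Where it says the series, first, only, none or still open, it means among the compounds named here.

Compound 1 (`COc1cc(-c2nccn2C(C)C)cc(OC)c1OC`) reports only a limit (> 100000 nM) in a functional assay on T47D cells (Homo sapiens) for antiproliferative activity, read by MTT assay, with a stated time of 72 h (on this read-out lower numbers stand for stronger inhibition and higher numbers for weaker inhibition), and no number. Compound 2 (`COc1cc(-c2nccn2CC(C)C)cc(OC)c1OC`) also reports only a limit (> 100000 nM) in this assay and so has no number of its own. Compound 3 (`CCCCCn1ccnc1-c1cc(OC)c(OC)c(OC)c1`) differs from compound 2 by butyl in place of isopropyl on a saturated chain carbon bound to an aromatic nitrogen and the change reads butyl in place of isopropyl on a saturated chain carbon bound to an aromatic nitrogen, or isobutyl to pentyl when cut one bond further out. Among the measured compounds shown here, the only measured step bearing on this is a step that the two limits leave unreadable from compound 1 to compound 2 and the evidence stops at the limit of > 100000 nM in this assay, at which 2 of the 2 values shown sit, with no size to carry over. No shift beyond the scatter is therefore expected in this assay in either direction. The estimate amounts to a number no higher from compound 2 to compound 3 (the limit leaves the size open) as the expected step. For compound 3 the estimated value is 100000 nM with an expected range from 30000 nM to 200000 nM and a report of a limit alone is the likeliest outcome.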

Compound 3, half-maximal inhibitory concentration: 64400 nM
Compound 3: middle estimate off by 1.6-fold (0.19 log units), on the high side; measured number inside the range.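

With pentyl on the aromatic nitrogen, compound 3 is the only one of the three to give a number in this assay, at 64400 nM. Set against the limits, this change reads as an at least 1.5-fold lower number from compound 2 to compound 3 (0.19 log units; that floor lies within the scatter) and as an at least 1.5-fold lower number from compound 1 to compound 3 (0.19 log units; that floor lies within the scatter); both are floors, so the true size stays open and neither shows a shift beyond the scatter. Compound 1 and compound 2 give limits rather than numbers, and the step between them cannot be read: the limit of > 100000 nM in this assay, at which 2 of the 3 values shown sit.

The compounds shown leave open whether a longer chain than pentyl on this nitrogen would lower the number further in this assay. They also do not say whether a chain carrying an amine or a carboxylic acid in this place would keep a readable number at all.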